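Trifluoromethyl for chloro on the aryl of compound 1

The source may hold more compounds than are shown below. What is called first, only, known or untested is meant among the compounds shown, and "the series" means these compounds.

Measured so far:
- Compound 1, `O=C(NO)c1ccc(NCc2nc(-c3ccc(Cl)cc3)nn2-c2ccccc2)cc1`: 67.2%
- Compound 2, `O=C(NO)c1ccc(NCc2nc(-c3ccccc3)nn2-c2ccc(Br)cc2)cc1`: 65.9%
- Compound 3, `CC(C)c1ccc(-n2nc(-c3ccccc3)nc2CNc2ccc(C(=O)NO)cc2)cc1`: 52.6%

These three compounds share one core and differ only in the groups on their outer aromatic rings. In an assay on Sf9 cells for inhibition of protein deacetylase HDAC6 (Homo sapiens), read by fluorescence, with a stated time of 40 min, tested at 100 nM (a higher number here means more inhibition at the concentration tested (going by the name of the read-out), a lower number less inhibition), compound 1 gives the highest of the three numbers, but its gap to compound 2 lies within the scatter, so the two cannot be ranked; compound 3 stands clearly lower than both.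

Compound 4, `O=C(NO)c1ccc(NCc2nc(-c3ccc(C(F)(F)F)cc3)nn2-c2ccccc2)cc1`, arises from compound 1 by a single change: trifluoromethyl in place of chloro on an aromatic carbon. Among the compounds with values here, only one measured step resembles this one, a number 13.3 percentage points lower from compound 2 to compound 3 (beyond the scatter), where a halogen on an aromatic carbon gave way to a larger carbon-based group. If the same holds here, compound 4 is expected to fall somewhat below compound 1, a modest drop of about a number 9.2 percentage points lower from compound 1 to compound 4 (within the scatter), though the single comparison leaves room for no change beyond the scatter. Compound 4 is therefore estimated at 58%, in the range 45% to 70%.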

Compound 4, a percentage reported as inhibition, at one concentration (the size of the read-out at that concentration, not a potency): 41.6%
Compound 4: middle estimate off by 16.4 percentage points, on the high side; measured number outside the range, below it.
By their numbers in this assay, from the lowest: compound 4; then compound 3; then compounds 2 and 1 (each within the scatter of the next).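

In this assay, replacing chloro with trifluoromethyl at this place, para to a large group, gives a number 25.6 percentage points lower from compound 1 to compound 4 (beyond the scatter). This shows that the number responds to which group sits on this outer ring, not only to changes on the other outer ring, where the earlier step from bromo to isopropyl was seen. In both steps, a single halogen gives way to a carbon-based group with more heavy atoms and the number falls, though two steps on different rings are a thin base for a pattern, and nothing measured here explains either drop.

One pair cannot separate the effect of the number of atoms in the new group from that of their kind. A methyl group, a methoxy group or an amine at the same place would help tell these apart, and the plain phenyl ring would show what the chloro itself contributes.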